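Notes on the cyclopropane-carboxamide series: pyridin-2-yl replacement

The source may hold more compounds than are shown below. What is called first, only, known or untested is meant among the compounds shown, and "the series" means these compounds.

Two compounds of this series carry measurements in a functional assay for agonist activity at G protein-coupled receptor 88 (Homo sapiens), read by HTRF and cAMP accumulation; on this read-out lower numbers stand for an effect already at smaller amounts and higher numbers for an effect only at larger amounts of compound. Compound 1, `N[C@H](CN(C(=O)[C@@H]1C[C@H]1c1ccccc1)c1ccc(-c2ccccc2)cc1)C1CCCCC1`, gives 0.66 nM in this assay. Compound 2, `CC[C@H](C)[C@H](N)CN(C(=O)[C@@H]1C[C@H]1c1cccc(Cl)c1)c1ccc(-c2ccccc2)cc1`, differs from compound 1 both in the amine side chain and in the aromatic ring on the three-membered ring. In this assay compound 2 gives 2200 nM; of the two numbers this is the higher one, and the gap to compound 1 lies well beyond the scatter. Among the measured compounds shown here, no single-point step between measured compounds is available, so the two values only bracket the range seen so far.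

Compound 3, `CC[C@H](C)[C@H](N)CN(C(=O)[C@@H]1C[C@H]1c1ccccn1)c1ccc(-c2ccccc2)cc1`, has not been measured. Its difference from compound 2 is pyridin-2-yl in place of 3-chlorophenyl on a saturated ring carbon. For the measured compounds named here, no measured pair isolates this change, so the expectation rests only on the two values above and on the fact that the side chain of compound 2 is kept unchanged. A step toward a lower number from compound 2 to compound 3 is expected, but of modest size and possibly within the scatter, written as a 1.8-fold lower number from compound 2 to compound 3 (0.26 log units; within the scatter). For compound 3 the estimate in this assay is 1200 nM, with a range from 250 nM to 6000 nM.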

Compound 3, half-maximal effective concentration: 130 nM
The estimate for compound 3 lay 9.2-fold (0.97 log units) above the measured number; the whole stated range lies above it.
By their numbers in this assay, from the lowest: compound 1; then compound 3; then compound 2.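

In this assay, the aromatic group on the three-membered ring now proves to matter on its own: with the amine side chain held fixed, pyridin-2-yl in place of 3-chlorophenyl gives a 17-fold lower number from compound 2 to compound 3 (1.23 log units; beyond the scatter) as a large step, something the earlier pair, differing in two places, could not isolate. The exchange alters several things at once: the chlorine leaves, a ring nitrogen enters with one hydrogen-bond acceptor, and the group is one heavy atom smaller, so this single step does not tell these parts apart. Nothing at hand bears on the cause of the step.

Still open, as far as these compounds go, is whether the lower number belongs to pyridin-2-yl itself or follows from the loss of chlorine; plain phenyl and pyridin-3-yl on the same side chain would separate these two readings. Equally open, from the compounds shown here alone, is whether the same exchange carries over to the cyclohexyl side chain of compound 1, or to other groups on the three-membered ring, such as a 3-methoxyphenyl.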